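The source may report more compounds than this note shows. Statements on the series, on what has been measured and on what is new or still open speak of the compounds shown alone.

In an ADME assay for permeability, using PAMPA (on this read-out higher numbers stand for higher permeability and lower numbers for lower permeability), compound 1 (`CC(C)(C)CCN1C(=O)C(C2=CS(=O)(=O)c3cc(NS(C)(=O)=O)ccc3N2)=C(O)[C@@H]1C(C)(C)C`) gives 1.8 10^-6 cm/s and compound 2 (`CC(C)(C)[C@H]1C(O)=C(C2=CS(=O)(=O)c3cc(NS(C)(=O)=O)ccc3N2)C(=O)N1Cc1ccc(F)cc1`) gives 1.4 10^-6 cm/s while compound 3 (`Cc1cc(CN2C(=O)C(C3=CS(=O)(=O)c4cc(NS(C)(=O)=O)ccc4N3)=C(O)[C@@H]2C(C)(C)C)ccc1F`) gives 1.62 10^-6 cm/s on the same scale. These three numbers all lie within the usual scatter of one another, so compound 3 stands level with the other two and not apart from them. Compound 4 (`CC(C)(C)[C@H]1C(O)=C(C2=CS(=O)(=O)c3cc(NS(C)(=O)=O)ccc3N2)C(=O)N1Cc1ccccc1`) has not been measured yet and differs from compound 3 in one place, with phenyl in place of 4-fluoro-3-methylphenyl on a saturated chain carbon bound to an amide-type nitrogen in a ring. The nearest guide is the swap of methyl in place of hydrogen on an aromatic carbon, which gave a 1.2-fold higher number from compound 2 to compound 3 (0.06 log units; within the scatter) as its result. Two wider swaps at the same place gave a 1.3-fold lower number from compound 1 to compound 2 (0.11 log units; within the scatter) and a 1.1-fold lower number from compound 1 to compound 3 (0.05 log units; within the scatter) as their results. Going by the values given here, no measured pair shows the fluorine leaving on its own. Among the compounds with values here, with a 1.2-fold higher number from compound 2 to compound 3 (0.06 log units; within the scatter) as the closest precedent, no step beyond the scatter is expected in this assay for this change. The estimate is a 1.1-fold lower number from compound 3 to compound 4 (0.03 log units; within the scatter) as the expected step. Compound 4 is therefore estimated at 1.5 10^-6 cm/s in this assay with a range of 0.9 10^-6 cm/s to 2.5 10^-6 cm/s expected for a single measurement.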

Compound 4, apparent permeability: 1.8 10^-6 cm/s
Beside the measured number, compound 4's estimate is 1.2-fold (0.08 log units) below it; the range from low to high includes it.
By their numbers in this assay, from the lowest: compounds 2, 3, 1 and 4 (each within the scatter of the next).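

In this assay, the step from 4-fluoro-3-methylbenzyl to benzyl on the amide-type nitrogen gives a 1.1-fold higher number from compound 3 to compound 4 (0.05 log units; within the scatter) and hydrogen in place of fluoro gives a 1.3-fold higher number from compound 2 to compound 4 (0.11 log units; within the scatter), so this position now has a measured pair showing the fluorine leaving on its own, and that step is as small as the methyl step seen earlier. Phenyl in place of neopentyl, an exchange of an aromatic ring for a branched carbon chain, gives no change at the digits printed from compound 1 to compound 4 (within the scatter), which means that neopentyl, benzyl and both substituted benzyl groups all read alike at this place, with every step among the four compounds within the scatter. Nothing measured here offers a reason for this flat picture.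

The compounds shown carry only carbon groups at this place, with or without fluorine, so it remains open whether an amine or a carboxylic acid there would move the number beyond the scatter. As far as these compounds go, it is also open whether the same swaps would stay this small on a core other than the shared one.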